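Methyl for Methoxy on Compound 3

A few compounds are considered here, and "the series" means these few. Any claim that something is new, unique, unknown or untested is made for them only; others in the source may bear on it.

Among the measured compounds shown here, in a functional assay on A549 cells (Homo sapiens) for antiproliferative activity, read by MTT assay, with a stated time of 48 h (on this read-out higher numbers stand for weaker inhibition and lower numbers for stronger inhibition), compound 3 (`COc1ccc(-c2nn(-c3ccccc3)cc2-c2nc3cc(OC)ccc3[nH]2)cc1`) gives 22700 nM and stands highest of the three numbers measured so far. Compound 1 (`Cc1ccc2[nH]c(-c3cn(-c4ccccc4)nc3-c3ccc(F)cc3)nc2c1`) gives 1440 nM and compound 2 (`Cc1ccc2[nH]c(-c3cn(-c4ccccc4)nc3-c3ccc(Cl)cc3)nc2c1`) gives 4640 nM in the same test, both lower than compound 3 by margins beyond the scatter. Compound 4 (`COc1ccc(-c2nn(-c3ccccc3)cc2-c2nc3cc(C)ccc3[nH]2)cc1`) departs from compound 3 in one place (methyl in place of methoxy on an aromatic carbon), with methyl in place of methoxy on an aromatic carbon. For the measured compounds named here, no measured step covers this exchange directly. Going by the values given here, the only single-place step is a 3.2-fold higher number from compound 1 to compound 2 (0.51 log units; beyond the scatter) and it is modest, but it concerns chloro in place of fluoro at a different place, so it shows only what size one exchange has reached in this small set. The methyl entering compound 4 is already carried by compound 1 and compound 2, although both also differ from compound 4 at that second place. A moderate step towards a lower number in this assay is therefore expected, with much uncertainty. The expected change is a 2.5-fold lower number from compound 3 to compound 4 (0.40 log units; beyond the scatter) on this estimate. For compound 4 the estimated value is 9000 nM (expected range 2500 nM to 28000 nM).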

Compound 4, half-maximal inhibitory concentration: 5070 nM
Compound 4: the middle estimate sits 1.8-fold (0.25 log units) above what was measured; the measured number falls inside the stated range.
By their numbers in this assay, from the lowest: compound 1; then compounds 2 and 4 (each within the scatter of the next); then compound 3.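

In this assay, among the compounds shown here, the exchange of methoxy for methyl on this aromatic carbon gives a 4.5-fold lower number from compound 3 to compound 4 (0.65 log units; beyond the scatter), the first direct reading at this position, since the earlier compounds carried methyl here but offered no methoxy to set against it. With methyl held in place, the second place can now be read with methoxy as well: methoxy in place of chloro gives a 1.1-fold higher number from compound 2 to compound 4 (0.04 log units; within the scatter), while methoxy in place of fluoro gives a 3.5-fold higher number from compound 1 to compound 4 (0.55 log units; beyond the scatter), so compound 1 remains apart from compound 4 whereas compound 2 and compound 4 cannot be told apart in this test. No measured information on these compounds accounts for either the size or the direction of these steps.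

What the compounds shown leave open is how an amine, a hydroxyl group or a longer chain such as ethyl would read on this same aromatic carbon, as only methoxy and methyl can be compared there. As far as these compounds go, the methoxy-to-methyl step also rests on a single pair that carries methoxy at the second place, so whether it would hold with fluoro or chloro at that place remains unknown.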